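The source may hold more compounds than are shown below. What is called first, only, known or untested is meant among the compounds shown, and "the series" means these compounds.

Measured so far in a functional assay on Caco-2 cells (Homo sapiens) for cytotoxicity, read by MTT assay, with stated times of 6 h and 48 h; a higher number here means a weaker inhibitor, a lower number a stronger inhibitor:

Compound 1, `Cn1c(/C=C/C(=O)c2ccccc2)cc(Br)c1Br`, gives >= 100000 nM.
Compound 2, `COc1ccc(OC)c(C(=O)/C=C/c2cc(Br)c(Br)n2C)c1`, gives >= 100000 nM.
Compound 3, `O=C(/C=C/c1cc(Br)c(Br)[nH]1)c1ccccc1`, gives >= 100000 nM.

Each of these three values is a limit of this assay and not a number. For compound 1 the value >= 100000 nM is such a limit. For compound 2 the value >= 100000 nM is likewise only a limit. For compound 3 the value >= 100000 nM is a limit as well, so that all three sit at the limit of >= 100000 nM in this assay, at which 3 of the 3 values shown sit.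

Compound 1 and compound 3 differ by one change, (hydrogen in place of methyl on an aromatic nitrogen). Because both sit at the limit, the step that the two limits leave unreadable from compound 1 to compound 3 cannot be read: its size is hidden by the two limits. How the core of compound 1 differs from the core of compound 2 is not broken down here.

Compound 4, `COc1ccc(OC)c(C(=O)/C=C/c2cc(Br)c(Br)[nH]2)c1`, is not yet measured in this assay. It stands to compound 2 as compound 3 stands to compound 1: the change hydrogen in place of methyl on an aromatic nitrogen is the same change, made on the other core. Since the earlier step left no readable size and every measured compound sits at the limit of >= 100000 nM in this assay, at which 3 of the 3 values shown sit, compound 4 is expected to behave the same way, and the step that the limit leaves unreadable from compound 2 to compound 4 is estimated to be small. For compound 4 a value of about 150000 nM is therefore expected in this assay, most likely reported again only as a limit, with 80000 nM and 300000 nM as the expected range.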

Compound 4, half-maximal inhibitory concentration: >= 100000 nM
Compound 4 ended at the assay's limit (the forecaster's own chance of this, stated with the estimate: 85%); the middle value does not contradict the limit.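

Among these compounds, compound 2 and compound 4 both end at a limit in this assay, so the step between them, hydrogen in place of methyl on an aromatic nitrogen, cannot be read, and no new step emerges. All the compounds shown stand at the same limit: the limit of >= 100000 nM in this assay, at which 4 of the 4 values shown sit.

The compounds shown leave open what size this change has on either core, and what any of the four would give as a number rather than a limit.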